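The compounds below may be only part of what the source reports. "The series", "measured", "known", "first", "only" and "open" are said of these compounds alone.

In a functional assay on SW480 cells (Homo sapiens) for antiproliferative activity, read by MTT assay, with a stated time of 48 h (a lower number here means a stronger inhibitor, a higher number a weaker inhibitor), compound 1 `CCCCCCCC(CCO)n1cnc2c(NC)ncnc21` gives 15300 nM. Compound 2 `CCCCCCCC(CCO)n1cnc2c(N(C)C)ncnc21` reads > 50000 nM, which is a limit of the assay and not a number. Within the data shown here, the only measured step is an at least 3.2-fold higher number from compound 1 to compound 2 (0.51 log units; beyond the scatter), and it comes with methyl in place of hydrogen on a nitrogen on an aromatic ring. Compound 3 `CCCCCCCCCCC(CCO)n1cnc2c(N(C)C)ncnc21` differs from compound 2 elsewhere, by propyl in place of hydrogen on a saturated chain carbon, eight bonds along the chain from an aromatic nitrogen. Among the measured compounds shown here, no measured step tests a change in this chain, so the step from compound 1 to compound 2 offers only a loose guide to size. A modest move towards a lower number in this assay is expected, though a second limit remains quite possible. The estimated step is an at least 1.7-fold lower number from compound 2 to compound 3 (0.25 log units; that floor lies within the scatter). For compound 3 the expected value is 28000 nM, with an estimated range of 9000 nM to 50000 nM.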

Compound 3, half-maximal inhibitory concentration: 3320 nM
Beside the measured number, compound 3's estimate is 8.4-fold (0.93 log units) above it; measured number outside the range, below it.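

The earlier compounds shown here left the chain untouched, and this change shows that it matters in this assay: propyl in place of hydrogen on a saturated chain carbon, eight bonds along the chain from an aromatic nitrogen, gives an at least 15-fold lower number from compound 2 to compound 3 (1.17 log units; beyond the scatter). The substituted nitrogen of compound 2 stays unchanged in compound 3, so this step belongs to the chain alone. Its true size stays unknown because compound 2 reads as a limit of the assay and not a number: the limit of > 50000 nM in this assay, at which 1 of the 3 values shown sits.

On these data alone, whether the same extension would lower the number as far on the nitrogen of compound 1 remains open. As far as these compounds go, it is also open whether a still longer chain, or a phenyl ring at the end of the chain, would continue the trend or reverse it.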